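The compounds below may be only part of what the source reports. "The series", "measured", "known", "first", "only" and "open" are said of these compounds alone.

Measured compounds:
- compound 1, `O=C(Nc1nn[nH]n1)c1cccc(Br)n1`: 48% in a functional assay on the whole organism for inhibition, with Rattus norvegicus as the target, at a dose of 10 mg/kg by the oral route; a higher number here means a stronger effect of the compound at the dose given, a lower number a weaker effect
- compound 2, `Cc1ccc(C(=O)Nc2nn[nH]n2)nc1`: 42%
- compound 3, `COc1ccnc(C(=O)Nc2nn[nH]n2)c1`: 88%

Among these three, compound 1 stands second highest. Its nearest neighbour is compound 2, whose number lies a little lower, and that gap is within the usual scatter of such measurements, so the two cannot be told apart. The furthest is compound 3, whose number lies well above that of compound 1, a gap beyond the scatter.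

The step under consideration leads from compound 1 to compound 4, `CCCCOc1cccc(C(=O)Nc2nn[nH]n2)n1`, which has not yet been measured. The change is butoxy in place of bromo on an aromatic carbon. For the measured compounds named here, no step between two measured compounds in this set shows the effect of such an exchange, so the expectation rests only on the numbers above and on the change itself. Compound 3, which carries an alkoxy group elsewhere on the shared core, gives the highest number seen here, whereas compound 1 with its bromo group sits lower. On that basis a moderate step upward from compound 1 to compound 4 is expected, though it may not clear the scatter; the expected step is a number 12 percentage points higher from compound 1 to compound 4 (beyond the scatter). For compound 4 the estimate is 60%, with a range from 32% to 85%.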

Compound 4, a percentage reported as inhibition, in the whole organism at one dose (the size of the read-out at that dose, not a potency): 8%
Beside the measured number, compound 4's estimate is 52 percentage points above it, outside the stated range (below it).
By their numbers in this assay, from the lowest: compound 4; then compounds 2 and 1 (each within the scatter of the next); then compound 3.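

In this assay, butoxy in place of bromo on the aromatic carbon next to the ring nitrogen gives a number 40 percentage points lower from compound 1 to compound 4 (beyond the scatter), a large step and the first measured at this place on the shared core. It shows that the effect at the dose given is not indifferent to what sits here: a group of 5 heavy atoms, with a hydrogen-bond acceptor, cannot simply stand in for the single bromine atom without a loss in this read-out. Nothing available on the compounds accounts for the size of this fall, so the step stands as an observation from one pair only.

The compounds shown leave open whether the fall follows the length of the chain, the ether oxygen or the loss of bromine itself, and a shorter ethoxy group, a butyl chain joined directly to the ring or a chlorine atom at the same place would separate these readings. They also leave open whether an amine or a carboxylic acid would be tolerated here, and whether the same exchange elsewhere on the core would produce a step of similar size.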